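The compounds below may be only part of what the source reports. "The series", "measured", "known", "first", "only" and "open" are said of these compounds alone.

Working notes on the indole-carboxamide series in a functional assay on HEK293 cells for agonist activity at growth hormone secretagogue receptor type 1 (Homo sapiens), read by HTRF and inositol phosphate accumulation, with a stated time of 90 min, in the presence of a further agent that is not named here; a lower number here means a smaller maximal response, a higher number a larger maximal response.

Compound 1 `Cc1ccc2[nH]c(C(=O)N[C@H]3CCN(S(=O)(=O)c4ccccc4)C[C@@H]3C(=O)NCCN(C)C)cc2c1` gives 98% in this assay. Compound 2 `Cc1ccc2[nH]c(C(=O)N[C@H]3CN(S(=O)(=O)c4ccccc4)C[C@@H]3C(=O)NC[C@H]3CCCN3C)cc2c1`, with a different ring size in the sulfonylated core and a basic side chain on the amide, gives 98% in this assay. Compound 2 stands level with compound 1 at the digits printed; the two values lie within the usual scatter of this kind of measurement, so no order between them can be read.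

Compound 3 `Cc1ccc2[nH]c(C(=O)N[C@H]3CN(S(=O)(=O)c4ccccc4)C[C@@H]3C(=O)N[C@H]3CCCNC3)cc2c1` is the next member to be measured. It differs from compound 2 in one place: piperidin-3-yl in place of (1-methylpyrrolidin-2-yl)methyl on an amide-type nitrogen. For the measured compounds named here, no step between measured compounds bears on this particular change, so the expectation rests on compound 1 and compound 2 alone, both of which reach a full maximal response. Going by the values given here, the series so far gives no sign that the amide side chain limits the maximal response, so the step is expected to be small, or none beyond the scatter, with a slight downward lean to allow for the unknown.

For compound 3 the maximal response in this assay is estimated at 94%, within 78% to 106%, a step of a number 4 percentage points lower from compound 2 to compound 3 (within the scatter) expected.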

Compound 3, largest response reached (Emax), in percent of the reference or control that the assay uses: 98%
The estimate for compound 3 lay 4 percentage points below the measured number, and the stated range covers the measured number.
By their numbers in this assay, from the lowest: compounds 1, 2 and 3 (each within the scatter of the next).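

At the amide-type nitrogen, piperidin-3-yl in place of (1-methylpyrrolidin-2-yl)methyl gives no change at the digits printed from compound 2 to compound 3 (within the scatter) in this assay. For the compounds shown here, this is the first change that can be read in one place, since compound 1 and compound 2 differ in more than one place and give no step. The exchange removes a five-membered non-aromatic ring and brings in a six-membered one with 1 hydrogen-bond donor, and the maximal response of compound 3, at 98%, shows no cost from it; nothing measured here gives a reason for this result.

Going by these compounds, what the side chain on this nitrogen can do to the maximal response remains open, as all three compounds read level at the top of the range and none shows a lowered response. A side chain without an amine, such as a plain butyl chain, or one ending in a carboxylic acid would test whether the ring amine is needed at all, and piperidin-3-yl on the core of compound 1 would show whether the result carries over to that core.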